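Swapping Fluoro for Chloro in a Cytotoxicity Series

The source may hold more compounds than are shown below. What is called first, only, known or untested is meant among the compounds shown, and "the series" means these compounds.

Compound 1 `COc1cc(/C=C2\CN(C)C/C(=C\c3ccc(F)cc3)C2=O)cc(OC)c1OC` and compound 2 `COc1cc(/C=C2\CN(C)C/C(=C\c3ccc(Cl)cc3)C2=O)cc(OC)c1OC` share a core and differ only in one place: chloro in place of fluoro on an aromatic carbon. In an ADME assay on L02 cells (Homo sapiens) for cytotoxicity, read by MTT assay, with a stated time of 24 h (on this read-out higher numbers stand for weaker inhibition and lower numbers for stronger inhibition), compound 1 gives 10700 nM, and compound 2 gives 14000 nM, so the change made a 1.3-fold higher number from compound 1 to compound 2 (0.12 log units; within the scatter). Compound 3 `CN1C/C(=C\c2ccc(F)cc2)C(=O)/C(=C/c2cccc([N+](=O)[O-])c2)C1` has a different core, and the difference between the two cores is not broken down here; in this assay compound 3 gives 17600 nM. Compound 4 `CN1C/C(=C\c2ccc(Cl)cc2)C(=O)/C(=C/c2cccc([N+](=O)[O-])c2)C1` is not yet measured and differs from compound 3 by the same change: chloro in place of fluoro on an aromatic carbon. Because the first occurrence gave a 1.3-fold higher number from compound 1 to compound 2 (0.12 log units; within the scatter), the step is expected to be a 1.2-fold higher number from compound 3 to compound 4 (0.08 log units; within the scatter). Compound 4 is therefore estimated to give 21000 nM, expected to lie between 10000 nM and 45000 nM.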

Compound 4, half-maximal inhibitory concentration: > 20000 nM
Compound 4 gave a limit, no number; the forecaster's own chance of this, stated with the estimate: 10%; the middle value lies beyond the limit too.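

The result for compound 4 in this assay is a limit of the assay and not a number, so the change from 4-fluorophenyl to 4-chlorophenyl on this core gives only a floor, an at least 1.1-fold higher number from compound 3 to compound 4 (0.05 log units; that floor lies within the scatter). Set side by side, the two occurrences of the change read: the same change on two cores in this assay, a 1.3-fold higher number (0.12 log units; within the scatter) from compound 1 to compound 2 and an at least 1.1-fold higher number (0.05 log units; that floor lies within the scatter) from compound 3 to compound 4; the limit leaves it open whether they differ. Nothing here goes against the change carrying over from one core to the other, yet nothing establishes it either: both readings lie within the scatter, and the second has no upper end.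

The compounds shown leave open how far beyond its limit compound 4 lies. They also leave open what a bromo group or an amine would do in the same place on the ring.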